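Swapping phenyl for pyridin-4-yl on compound 1

This account rests on a few compounds, and the source may have more. Where it says the series, first, only, none or still open, it means among the compounds named here.

- compound 1 `C=CCOc1cc(OC)c(C(=O)/C=C/c2ccccc2)c(OCC=C)c1`: 17100 nM
- compound 2 `C=CCOc1cc(OC)c(C(=O)/C=C/c2ccccn2)c(OCC=C)c1`: 2800 nM
- compound 3 `C=CCOc1cc(OC)c(C(=O)/C=C/c2ccc(C)cc2)c(OCC=C)c1`: 211000 nM

All three compounds were tested in an ADME assay on Vero cells (Chlorocebus sabaeus) for cytotoxicity, read by MTT assay; a higher number here means a weaker inhibitor, a lower number a stronger inhibitor. Compound 1 stands in the middle of the three numbers, at 17100 nM. Its two neighbours lie clearly on either side of it: the measured steps are a 6.1-fold lower number from compound 1 to compound 2 (0.79 log units; beyond the scatter) and a 12-fold higher number from compound 1 to compound 3 (1.09 log units; beyond the scatter).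

The untested compound 4 `C=CCOc1cc(OC)c(C(=O)/C=C/c2ccncc2)c(OCC=C)c1` differs from compound 1 in one place: pyridin-4-yl in place of phenyl on a double-bonded chain carbon bound to a double-bonded chain carbon. Put simply, pyridin-4-yl stands in place of phenyl on a double-bonded chain carbon bound to a double-bonded chain carbon.

The closest guide is compound 2, where pyridin-2-yl replaces phenyl at that same place, giving a 6.1-fold lower number from compound 1 to compound 2 (0.79 log units; beyond the scatter). The step to compound 3 is a different change, an extra methyl, so it says little about direction here. It does show how far one small change can move the number, at a 12-fold higher number from compound 1 to compound 3 (1.09 log units; beyond the scatter).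

A single pyridin-2-yl example cannot show what pyridin-4-yl will do, so the expectation stays loose. The expected change is a modest drop, estimated as a 3.4-fold lower number from compound 1 to compound 4 (0.53 log units; beyond the scatter). Compound 4 is estimated at 5000 nM, with an expected range from 1500 nM to 16000 nM.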

Compound 4, half-maximal inhibitory concentration: 2800 nM
Estimate against measurement, compound 4: 1.8-fold (0.25 log units) above; the range from low to high includes it.
By their numbers in this assay, from the lowest: compounds 2 and 4 (each within the scatter of the next); then compound 1; then compound 3.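

In this assay, the new pyridin-4-yl group on the double-bonded chain carbon lowers the number as well (a 6.1-fold lower number from compound 1 to compound 4 (0.79 log units; beyond the scatter)), so the drop no longer rests on the pyridin-2-yl example alone. Exchanging pyridin-2-yl for pyridin-4-yl shows no real difference (no change at the digits printed from compound 2 to compound 4 (within the scatter)), and for these two groups the place of the ring nitrogen does not register in this measurement, while pyridin-4-yl in place of 4-methylphenyl spans a far larger gap (a 75-fold lower number from compound 3 to compound 4 (1.88 log units; beyond the scatter)). No measurement at hand explains why these swaps move the number as they do.

Pyridin-3-yl, the remaining single-nitrogen ring of this kind, could show whether the match between pyridin-2-yl and pyridin-4-yl holds across the series, and a pyrimidinyl ring could show what a second ring nitrogen does. A phenyl ring carrying an amine or a carboxylic acid in place of the methyl would test whether the large rise seen with 4-methylphenyl is specific to methyl or extends to other groups at that spot.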